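Moving a Triple Bond One Position Along the Chain

The source may hold more compounds than are shown below. What is called first, only, known or untested is meant among the compounds shown, and "the series" means these compounds.

Compound 1 `CC[C@H](C)Cn1c(Cc2cc(OC)c(OC)c(OC)c2)nc2c(N)nc(F)nc21` and compound 2 `CC#CCCn1c(Cc2cc(OC)c(OC)c(OC)c2)nc2c(N)nc(F)nc21` share one core and differ only in the chain on the aromatic nitrogen. In a functional assay on MCF7 cells (Homo sapiens) for antiproliferative activity (a lower number here means a stronger inhibitor, a higher number a weaker inhibitor), compound 1 gives 43700 nM, and compound 2 gives 37200 nM; the step of a 1.2-fold lower number from compound 1 to compound 2 (0.07 log units; within the scatter) lies within the scatter, so compound 2 holds the lower of the two numbers without being set apart. Compound 3 `C#CCCCn1c(Cc2cc(OC)c(OC)c(OC)c2)nc2c(N)nc(F)nc21` differs from compound 2 by propargyl in place of prop-1-yn-1-yl on a saturated chain carbon, two bonds along the chain from an aromatic nitrogen. For the measured compounds named here, the one measured step bearing on this, a 1.2-fold lower number from compound 1 to compound 2 (0.07 log units; within the scatter), was small, so the shift is expected to stay within the scatter: a 1.0-fold lower number from compound 2 to compound 3 (0.00 log units; within the scatter). Compound 3 is therefore estimated at 37000 nM, between 15000 nM and 90000 nM.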

Compound 3, half-maximal inhibitory concentration: 11000 nM
The estimate for compound 3 lay 3.4-fold (0.53 log units) above the measured number; the measured number lies below the stated range.
By their numbers in this assay, from the lowest: compound 3; then compounds 2 and 1 (each within the scatter of the next).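

Swapping but-2-yn-1-yl for but-3-yn-1-yl keeps the same atoms, yet in this assay it gives a 3.4-fold lower number from compound 2 to compound 3 (0.53 log units; beyond the scatter), whereas replacing sec-butyl with but-2-yn-1-yl had stayed within the scatter. With but-3-yn-1-yl the chain also separates from sec-butyl, with a 4.0-fold lower number from compound 1 to compound 3 (0.60 log units; beyond the scatter), so at this position the place of the triple bond in the chain goes with the number, not its mere presence. No measurement shown accounts for this difference. On these data alone, whether the step would hold with pent-4-yn-1-yl, a longer chain, remains open, as does the effect of an amine on this chain.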